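Notes on the amide series: compound 2 to compound 3

The compounds below may be only part of what the source reports. "The series", "measured", "known", "first", "only" and "open" are said of these compounds alone.

Measured so far in a physicochemical assay for solubility, measured as kinetic solubility, with a stated time of 1 h, at pH 7.4; a lower number here means a less soluble compound, a higher number a more soluble compound
compound 1 `CC(=O)Nc1nc(-c2ccc(Cl)c(Cl)c2)cs1` gives < 1000 nM (a limit)
compound 2 `O=C(Nc1nc(-c2ccc(Cl)c(Cl)c2)cs1)c1cncs1` gives 2000 nM

For the measured compounds named here, compound 2 holds the only number, 2000 nM, in this assay. Compound 1 has a limit and no number: the limit of < 1000 nM in this assay, at which 1 of the 2 values shown sits. Compound 3 `O=C(Nc1nc(-c2ccc(Cl)c(Cl)c2)cs1)c1cccnc1` differs from compound 2 as follows: pyridin-3-yl in place of 1,3-thiazol-5-yl on a carbonyl carbon. Going by the values given here, the one measured step on this carbonyl carbon is an at least 2.0-fold higher number from compound 1 to compound 2 (0.30 log units; that floor lies within the scatter), and it replaces methyl, not a ring. No exchange of one ring for another has been measured, so no step beyond the scatter is expected. The expected step is no change at the digits printed from compound 2 to compound 3 (within the scatter). For compound 3 the estimate is 2000 nM, with an expected range from 1000 nM to 6000 nM.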

Compound 3, solubility: 20000 nM
Estimate against measurement, compound 3: 10-fold (1.00 log units) below; the whole stated range lies below it.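

In this assay, the number at this carbonyl carbon depends on which ring sits there, not only on whether a ring is present: pyridin-3-yl in place of 1,3-thiazol-5-yl gives a 10-fold higher number from compound 2 to compound 3 (1.00 log units; beyond the scatter), the only ring-for-ring exchange shown. Pyridin-3-yl in place of methyl gives an at least 20-fold higher number from compound 1 to compound 3 (1.30 log units; beyond the scatter). That step is a floor and not a full size, because compound 1 stands at a limit: the limit of < 1000 nM in this assay, at which 1 of the 3 values shown sits.

The exchange changes ring size and hetero atoms together, and the compounds shown do not separate the two. Also open, on these data alone, is how an amine or a carboxylic acid on this carbonyl carbon would read.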